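A triazolyl group takes the place of a fluoro

The source may hold more compounds than are shown below. What is called first, only, known or untested is meant among the compounds shown, and "the series" means these compounds.

The measured compounds:
Compound 1 `CC1(OC(=O)N2C[C@H]3COC[C@@H](C2)[C@@H]3Oc2ncnc(Nc3ccccc3F)c2F)CC1` gives 76% in a functional assay for agonist activity at Glucose-dependent insulinotropic receptor (Mus musculus), read by cAMP accumulation; on this read-out lower numbers stand for smaller maximal responses and higher numbers for larger maximal responses.
Compound 2 `CC1(OC(=O)N2CC3COCC(C2)C3Oc2ncnc(Oc3ccccc3F)c2F)CC1` gives 136% in this assay.
Compound 3 `CC1(OC(=O)N2CC3COCC(C2)C3Oc2ncnc(Nc3ccc(F)cc3F)c2F)CC1` gives 73% in this assay.

Among these three numbers compound 3 stands lowest, but its nearest neighbour is compound 1, whose value lies within the scatter of it, so the two cannot be ranked. Among the measured compounds shown here, the only step beyond the scatter runs a number 63 percentage points lower from compound 2 to compound 3 (beyond the scatter), and that change swapped the linking group and added a fluoro at the same time.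

Compound 4 `CC1(OC(=O)N2CC3COCC(C2)C3Oc2ncnc(Nc3ccc(-n4cncn4)cc3F)c2F)CC1` differs from compound 3 by 1H-1,2,4-triazol-1-yl in place of fluoro on an aromatic carbon. None of the measured steps touches this position: the step from compound 2 to compound 3 concerns the link to the aromatic ring and a different fluoro, and nothing shown varies the group para to a large group. For the measured compounds named here, the account therefore has no step to lean on, and the expected change is none beyond the scatter, an estimated a number 2 percentage points higher from compound 3 to compound 4 (within the scatter). Compound 4 is expected to give 75%, with a range from 50% to 105%.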

Compound 4, largest response reached (reported as percent of maximum), in percent of the reference or control that the assay uses: 83%
For compound 4 the middle estimate is 8 percentage points below the measured one; the range from low to high includes it.
By their numbers in this assay, from the lowest: compounds 3, 1 and 4 (each within the scatter of the next); then compound 2.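

In this assay, replacing fluoro with 1H-1,2,4-triazol-1-yl, para to a large group, gives a number 10 percentage points higher from compound 3 to compound 4 (within the scatter). Among the compounds shown here, the position therefore takes a five-membered aromatic ring of 5 heavy atoms in place of a single fluorine, with no change that can be told from the scatter, which the earlier compounds could not show because none of them varied this group. No measurement bears on why the response is tolerated here.

The compounds shown leave open whether a morpholine, a carboxylic acid or a nitrile at this position would fare the same, since only fluoro and the triazolyl group are compared here. On these data alone, it also remains open whether the triazolyl group would behave alike on the oxygen-linked compound 2.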